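From Compound 2 to Compound 3 in Paw Edema

The source may hold more compounds than are shown below. What is called first, only, known or untested is meant among the compounds shown, and "the series" means these compounds.

Compound 1 `CCCSCCc1cc(-c2ccc(S(C)(=O)=O)cc2)n(-c2ccccc2)c1C` and compound 2 `CCCSCCc1cc(-c2ccc(S(C)(=O)=O)cc2)n(-c2ccc(F)cc2)c1C` share one core. In a functional assay on the whole organism for inhibition, with Rattus norvegicus as the target, read by paw edema, with stated times of 4 h and 1 h, at a dose of 20 mg/kg by the oral route (a lower number here means less inhibition, a higher number more inhibition at the dose given (going by the name of the read-out)), compound 1 gives 100%, and compound 2 gives 100%, so compound 2 stands level with compound 1. Going by the values given here, the only measured step, no change at the digits printed from compound 1 to compound 2 (within the scatter), lies within the scatter. Compound 3 `CCC[S+]([O-])CCc1cc(-c2ccc(S(C)(=O)=O)cc2)n(-c2ccc(F)cc2)c1C` differs from compound 2 in one place: a group of 5 heavy atoms (3 carbon, 1 oxygen, 1 sulfur; no ring) in place of a group of 4 heavy atoms (3 carbon, 1 sulfur; no ring), on a saturated chain carbon, two bonds along the chain from an aromatic carbon. Among the compounds with values here, no measured step touches the propylsulfanyl group, so the fluoro step offers no guide, and both known values already sit at the top of the read-out. A step of a number 15 percentage points lower from compound 2 to compound 3 (beyond the scatter) is expected. Compound 3 is therefore estimated at 85%, with a range from 50% to 100%.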

Compound 3, a percentage reported as inhibition, in the whole organism at one dose (the size of the read-out at that dose, not a potency): 100%
Compound 3: the middle estimate sits 15 percentage points below what was measured, and the stated range covers the measured number.
By their numbers in this assay, from the lowest: compounds 1, 2 and 3 (each within the scatter of the next).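

In this assay, going by these compounds alone, the first change at this position, a group of 5 heavy atoms with one oxygen in place of propylsulfanyl, gives no change at the digits printed from compound 2 to compound 3 (within the scatter). On the saturated chain carbon, this added oxygen therefore leaves the reading at this single dose unmoved, though a dose this high may not separate compounds that differ in potency. Nothing here explains the result.

As far as these compounds go, whether a sulfone, with a second oxygen, a longer chain or an amine at this place would give the same reading stays open. So does the effect of these changes at lower doses.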